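One stereocentre inverted: what to expect for compound 3

The compounds below may be only part of what the source reports. "The series", "measured", "known", "first", "only" and "open" are said of these compounds alone.

Measured so far in a functional assay on MCF7 cells (Homo sapiens) for inhibition, read by fluorescence, with a stated time of 72 h; on this read-out lower numbers stand for stronger inhibition and higher numbers for weaker inhibition:
- compound 1 `CC(C)n1cnc2c(NC(=N)N)nc(N)nc21`: 97200 nM
- compound 2 `CC(C)[C@@H](N)COc1nc(NC(=N)N)c2ncn(C(C)C)c2n1`: 79400 nM

Compound 2 and compound 1 lie within the scatter of each other, so neither can be said to lead. Compound 3 `CC(C)[C@H](N)COc1nc(NC(=N)N)c2ncn(C(C)C)c2n1` is a close relative of compound 2: the two compounds have the same atoms and bonds; at least one stereo element is drawn with a configuration in one of them and without one in the other: 1 of 2 stereo elements differ; a stereocentre at a saturated chain carbon is drawn R in compound 2 and S in compound 3. The stereocentre at a saturated chain carbon is drawn R in compound 2 and S in compound 3.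

Among the measured compounds shown here, only one measured step bears on this, the exchange of amino on an aromatic carbon for 2-amino-3-methylbutoxy: a 1.2-fold lower number from compound 1 to compound 2 (0.09 log units; within the scatter). For the measured compounds named here, that step concerns the whole group, and no measured pair shows what a change of configuration does. A step beyond the scatter in this assay is therefore not expected, and no direction can be favoured. The estimated change is a 1.1-fold lower number from compound 2 to compound 3 (0.02 log units; within the scatter). For compound 3 the expected value is 75000 nM, with an estimated range of 35000 nM to 120000 nM.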

Compound 3, half-maximal inhibitory concentration: 3400 nM
Compound 3: middle estimate off by 22-fold (1.34 log units), on the high side, outside the stated range (below it).
By their numbers in this assay, from the lowest: compound 3; then compounds 2 and 1 (each within the scatter of the next).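

In this assay, the configuration of the side chain turns out to count for far more than its presence: with the stereocentre at the saturated chain carbon drawn S instead of R, there is a 23-fold lower number from compound 2 to compound 3 (1.37 log units; beyond the scatter). The 2-amino-3-methylbutoxy group, which made no difference beyond the scatter when drawn R, does make one in place of amino when drawn S, with a 29-fold lower number from compound 1 to compound 3 (1.46 log units; beyond the scatter). The gap between the two side chains therefore comes down to a single feature of their structures: the fact that one of compounds 2 and 3 is drawn with a defined configuration and the other without, at the place where they differ

Why one configuration gives so much lower a number cannot be told from these three compounds. Going by these compounds, it also remains open whether the S chain would keep this advantage with a hydroxyl group in place of its amine, or as a longer chain.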